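The source may report more compounds than this note shows. Statements on the series, on what has been measured and on what is new or still open speak of the compounds shown alone.

Three compounds have so far been measured in a functional assay on the whole organism with Mus musculus as the target, in the writhing test, at a dose of 100 mg/kg by the intraperitoneal route; a higher number here means more inhibition at the dose given (going by the name of the read-out), a lower number less inhibition:

Compound 1, `Brc1ccc(OCCOc2nc3ccccc3s2)cc1`, gives 68.6%.
Compound 2, `Brc1cccc(COc2nc3ccccc3s2)c1`, gives 51.9%.
Compound 3, `Clc1ccc(OCCOc2nc3ccccc3s2)cc1`, gives 68.6%.

Compound 1 and compound 3 differ in one place only, by chloro in place of bromo on an aromatic carbon. The step of no change at the digits printed from compound 1 to compound 3 (within the scatter) shows that swapping one halogen for the other at this place left the read-out where it was. Compound 2 stands lowest of the three; compound 1 and compound 3 both lie beyond the scatter above it. Compound 2 and compound 1 differ in more than one place, and the difference between the two cores is not broken down here.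

The next compound, compound 4, `Clc1cccc(COc2nc3ccccc3s2)c1`, has not yet been measured in this assay. It differs from compound 2 by chloro in place of bromo on an aromatic carbon. Among the compounds with values here, this is the same kind of change as the one from compound 1 to compound 3, but not the same: there the halogen sits para to a large group, here meta to a large group, and the two cores also differ.

For compound 4 the step of a number 0.1 percentage points higher from compound 2 to compound 4 (within the scatter) is expected, resting on the unchanged read-out seen in no change at the digits printed from compound 1 to compound 3 (within the scatter) for the same kind of swap. Compound 4 is therefore estimated at 52%, with a likely range from 40% to 64%.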

Compound 4, a percentage reported as inhibition, in the whole organism at one dose (the size of the read-out at that dose, not a potency): 51.9%
Estimate against measurement, compound 4: 0.1 percentage points above, and the stated range covers the measured number.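

In this assay, putting chloro in place of bromo on an aromatic carbon gave no change at the digits printed from compound 2 to compound 4 (within the scatter), so the swap that left the read-out in place on the core of compound 1 did the same on the core of compound 2. Set side by side, the two steps agree: the same change on two cores in this assay, no change at the digits printed (within the scatter) from compound 1 to compound 3 and no change at the digits printed (within the scatter) from compound 2 to compound 4, 0 percentage points apart, within the scatter of two such steps
This shows that, for these two cores, the bromo and chloro compounds can be treated as interchangeable in this read-out, whether the halogen sits para or meta to a large group, but it does not show a general rule: two cores are a small sample, a step with no visible size is a weak test of transfer, and a single dose gives the size of the effect at that dose rather than a potency, so the pairs could still separate at other doses.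

The compounds shown leave open whether a change that does move the read-out would carry from one core to the other in the same way, since only this one halogen swap appears on both cores. They also leave open what would follow if a methoxy group, a nitrile or an amine took the place of the halogen, or if a longer chain joined the halogen-bearing ring to the rest of the molecule.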